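Triazole aryl swap: thiophene in place of tolyl

This account rests on a few compounds, and the source may have more. Where it says the series, first, only, none or still open, it means among the compounds named here.

Compound 1 `CCS[C@@H]1[C@H](SCC)[C@@H](Cn2cc(-c3ccccc3)nn2)O[C@H]1n1ccc(=O)[nH]c1=O` gives 3040 nM in a functional assay on A549 cells (Homo sapiens) for cytotoxicity, read by MTT assay, with a stated time of 72 h; a lower number here means that less compound is needed, a higher number that more compound is needed for the effect. For the measured compounds named here, compound 2 `CCS[C@@H]1[C@H](SCC)[C@@H](Cn2cc(-c3cccc(C)c3)nn2)O[C@H]1n1ccc(=O)[nH]c1=O` gives 12200 nM in this assay, the higher of the two numbers measured, and the single step known, a 4.0-fold higher number from compound 1 to compound 2 (0.60 log units; beyond the scatter), separates them. Compound 3 `CCS[C@@H]1[C@H](SCC)[C@@H](Cn2cc(-c3cccs3)nn2)O[C@H]1n1ccc(=O)[nH]c1=O` differs from compound 2 by thiophen-2-yl in place of 3-methylphenyl on an aromatic carbon. Going by the values given here, no measured step covers a thiophen-2-yl at this position. A number nearer compound 1 is nonetheless expected because a 4.0-fold higher number from compound 1 to compound 2 (0.60 log units; beyond the scatter) came with adding a methyl that compound 3 lacks. The expected step is therefore a 2.7-fold lower number from compound 2 to compound 3 (0.43 log units; beyond the scatter). Compound 3 is estimated at 4500 nM, with a range from 1500 nM to 13000 nM.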

Compound 3, half-maximal effective concentration: >= 100000 nM
Compound 3 gave a limit, no number; the forecaster's own chance of this, stated with the estimate: 5%; middle value at least 22-fold (1.34 log units) from the limit.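

Compound 3 gives a limit in this assay, not a number: the limit of >= 100000 nM in this assay, at which 1 of the 3 values shown sits.
Even so, both steps can be read in one direction: an at least 8.1-fold higher number from compound 2 to compound 3 (0.91 log units; beyond the scatter) and an at least 32-fold higher number from compound 1 to compound 3 (1.51 log units; beyond the scatter).
At this position, the identity of the aromatic ring therefore counts for more than the methyl on the phenyl ring, and the phenyl of compound 1 stays lowest of the three.

Open, as far as these compounds go, is how far compound 3 lies past its limit. Also open, from the compounds shown here alone, is whether thiophen-3-yl, pyridin-3-yl or a phenyl ring carrying an amine would stay near compound 1.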